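Phenyl for Methyl on the Aryl Oxygen: Expected Hemolysis Inhibition

The compounds below may be only part of what the source reports. "The series", "measured", "known", "first", "only" and "open" are said of these compounds alone.

Compound 1 `CC1(C)Cc2c(O)cc(C=O)cc2O1`: > 1560000 nM
Compound 2 `CC1(C)Cc2c(O)cc(C(=O)O)cc2O1`: > 1440000 nM
Compound 3 `COc1cc(C=O)cc2c1CC(C)(C)O2`: 1100000 nM

Going by the values given here, in a functional assay on the whole organism with Homo sapiens as the target, read by hemolysis (a lower number here means a stronger inhibitor, a higher number a weaker inhibitor), compound 3 gives 1100000 nM, the only number among the three. The result for compound 1 is a limit of the assay, not a number. The result for compound 2 is likewise a limit. Among the compounds with values here, the step of an at least 1.4-fold lower number from compound 1 to compound 3 (0.15 log units; that floor lies within the scatter) is the only measured change at the same oxygen, and the step that the two limits leave unreadable from compound 1 to compound 2 cannot be read. Compound 4 `CC1(C)Cc2c(Oc3ccccc3)cc(C=O)cc2O1` differs from compound 3 by phenyl in place of methyl on an oxygen on an aromatic ring. Within the data shown here, no measured step exchanges a methyl for a phenyl, so the expectation rests on the one change at that oxygen, which stayed within the scatter. Compound 4 is therefore expected to show a modest lowering, a 2.2-fold lower number from compound 3 to compound 4 (0.34 log units; beyond the scatter), to about 500000 nM in this assay, within 150000 nM to 1500000 nM.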

Compound 4, half-maximal inhibitory concentration: > 1120000 nM
Compound 4 was reported as a limit (the forecaster's own chance of this, stated with the estimate: 25%); at least 2.2-fold (0.35 log units) between middle value and limit.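

The result for compound 4 is a limit of the assay and not a number: the limit of > 1120000 nM in this assay, at which 1 of the 4 values shown sits.

In this assay, phenyl in place of methyl on this oxygen gives an at least 1.0-fold higher number from compound 3 to compound 4 (0.00 log units; that floor lies within the scatter), so the larger group shows no stronger inhibition than methyl, and compound 3 remains the only one of the four with a number. The step between compound 1 and compound 4 cannot be read.

From the compounds shown here alone, it remains open whether an ethyl group, a longer chain or a chain ending in an amine on this oxygen would give a number. Going by these compounds, how far compound 4 lies past its limit also remains open.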